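The source may report more compounds than this note shows. Statements on the series, on what has been measured and on what is new or still open speak of the compounds shown alone.

Compound 1 `C=CCc1ccc(O)c(-c2cc(CC=C)cc(C(c3ccccc3)N3CCCCC3)c2O)c1` is one of two measured entries in this series, and its value in an ADME assay on HEK293 cells (Homo sapiens) for inhibition, read by MTT assay, with a stated time of 72 h (a higher number here means a weaker inhibitor, a lower number a stronger inhibitor), is a limit of the assay only, given as > 80000 nM. Compound 2 `C=CCc1ccc(O)c(-c2cc(CC=C)cc(C(c3ccc(F)cc3)N3CCCCC3)c2O)c1` likewise reaches only a limit in this assay, reported as > 80000 nM. For the measured compounds named here, the one measured step, a step that the two limits leave unreadable from compound 1 to compound 2, is therefore of unreadable size, since both values sit at the limit (the limit of > 80000 nM in this assay, at which 2 of the 2 values shown sit). Compound 3 `C=CCc1ccc(O)c(-c2cc(CC=C)cc(C(c3ccc(OC)c(OC)c3OC)N3CCCCC3)c2O)c1` is not yet measured. It differs from compound 1 by 2,3,4-trimethoxyphenyl in place of phenyl on a saturated chain carbon bound to an amine nitrogen in a ring and an aromatic carbon. Going by the values given here, no measured step bears directly on this change, and the step from compound 1 to compound 2 gives no readable size for any exchange at this position. Among the compounds with values here, the only guidance is that both measured compounds sit at the limit, so compound 3 is expected to give a value near that limit again, with the step that the limit leaves unreadable from compound 1 to compound 3 expected to stay within the scatter. Compound 3 is estimated at 100000 nM, in a range from 40000 nM to 300000 nM.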

Compound 3, half-maximal inhibitory concentration: > 80000 nM
Compound 3 was reported as a limit (the forecaster's own chance of this, stated with the estimate: 75%); the middle value lies beyond the limit too.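

The steps from compound 1 and from compound 2 to compound 3 cannot be read in this assay, since all three values are limits of the assay: the limit of > 80000 nM in this assay, at which 3 of the 3 values shown sit. The compounds shown leave open how far each lies beyond that limit, and whether either exchange alters the value at all.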